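This account rests on a few compounds, and the source may have more. Where it says the series, first, only, none or still open, it means among the compounds named here.

Measured so far in a functional assay with Homo sapiens as the target; on this read-out higher numbers stand for weaker inhibition and lower numbers for stronger inhibition:
compound 1 (`CC(C)(C)c1ccc(NC(=O)c2ccc(Cl)[n+]([O-])c2)cc1`) gives 1300 nM
compound 2 (`O=C(NC1CCCCC1)c1ccc(Cl)[n+]([O-])c1`) gives > 20000 nM as a limit
compound 3 (`O=C(Nc1ccc(F)cc1)c1ccc(S(=O)(=O)C2CCCC2)[n+]([O-])c1`) gives 1900 nM

Compound 3 at 1900 nM and compound 1 at 1300 nM lie within the usual scatter of each other, so this read-out cannot tell them apart. Compound 2 reports only a limit of the assay, > 20000 nM in this case.

The next compound to be tested, compound 4 (`O=C(Nc1ccc(F)cc1)c1ccc(S(=O)(=O)Cc2ccccc2)[n+]([O-])c1`), carries benzyl in place of cyclopentyl on a sulfonyl sulfur. Going by the values given here, no measured pair in this assay shows a change at this place, so there is no direct guide to its effect. The expectation rests on compound 3 at 1900 nM and is for no step beyond the scatter, in either direction. The estimated change is a 1.1-fold higher number from compound 3 to compound 4 (0.02 log units; within the scatter) and no more than that is expected. For compound 4 the estimate is 2000 nM with an expected range from 700 nM to 6000 nM in this measurement.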

Compound 4, half-maximal inhibitory concentration: 1000 nM
For compound 4 the middle estimate is 2.0-fold (0.30 log units) above the measured one; the range from low to high includes it.
By their numbers in this assay, from the lowest: compounds 4, 1 and 3 (each within the scatter of the next). At a limit, above all of these: compound 2.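

In this assay, going by these compounds alone, the first step at this place, a 1.9-fold lower number from compound 3 to compound 4 (0.28 log units; within the scatter), shows that benzyl in place of cyclopentyl on a sulfonyl sulfur does not shift the read-out beyond the scatter. A five-membered non-aromatic carbon ring and a benzyl group carrying a six-membered aromatic ring therefore cannot be told apart at this position, and the aromatic ring brings no measurable gain or loss. Nothing among the data shown offers a cause for this step.

Going by these compounds, the two groups compared here are both carbon-only rings, so it remains open whether a sulfonyl substituent such as a small methyl, a piperidine or a chain ending in an amine would move the number beyond the scatter. On these data alone, it is equally open whether a carboxylic acid on the benzyl ring would do so.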